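Swapping a saturated ring for an aromatic one

The source may hold more compounds than are shown below. What is called first, only, known or untested is meant among the compounds shown, and "the series" means these compounds.

Going by the values given here, compound 2 `CNC(=O)c1cccc(Cn2nc(C)c(NC(=O)c3ccc(COC4CCCCC4)cc3)c2C)c1` gives 14000 nM in a functional assay on MIA PaCa-2 cells (Homo sapiens) for antiproliferative activity, read by MTT assay, with a stated time of 72 h (a lower number here means that less compound is needed, a higher number that more compound is needed for the effect), the highest of the two numbers so far. Compound 1 `CNC(=O)c1cccc(Cn2nc(C)c(NC(=O)c3ccc(COc4ccccc4)cc3)c2C)c1` gives 6200 nM in this assay; the step of a 2.3-fold higher number from compound 1 to compound 2 (0.35 log units; beyond the scatter) is the only one measured. Compound 3 `CNC(=O)c1cccc(Cn2nc(C)c(NC(=O)c3ccc(COc4ccccc4C)cc3)c2C)c1` differs from compound 2 by 2-methylphenyl in place of cyclohexyl on an oxygen on a saturated carbon, which returns to an aromatic ring like that of compound 1, now bearing a methyl. Reversing the measured step suggests a modest downward move, so compound 3 is expected to give 6500 nM in this assay, between 2800 nM and 15000 nM, a step of a 2.2-fold lower number from compound 2 to compound 3 (0.33 log units; beyond the scatter).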

Compound 3, half-maximal effective concentration: 2100 nM
Compound 3: middle estimate off by 3.1-fold (0.49 log units), on the high side; the measured number lies below the stated range.
By their numbers in this assay, from the lowest: compound 3; then compound 1; then compound 2.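

On the oxygen of this side chain, 2-methylphenyl in place of cyclohexyl gives a 6.7-fold lower number from compound 2 to compound 3 (0.82 log units; beyond the scatter) in this assay and so reaches the lowest number of the three compounds. The return to an aromatic ring is not the whole story, since methyl in place of hydrogen on that ring gives a 3.0-fold lower number from compound 1 to compound 3 (0.47 log units; beyond the scatter) on its own, a gain that compound 1 could not reveal. Nothing available here explains why the methyl lowers the number.

Going by these compounds, whether an ethyl group, a chlorine atom or an amine in place of that methyl would lower the number further remains open.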